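The source may report more compounds than this note shows. Statements on the series, on what has been measured and on what is new or still open speak of the compounds shown alone.

Series notes. Compound 1 `Cc1cccc(C)c1-c1cccc(COc2ccc(CCC(=O)O)c(F)c2)c1` is the parent of this pair. Within the data shown here, in an assay on CHO cells for displacement of a labelled ligand from Free fatty acid receptor 1 (Rattus norvegicus), read by scintillation counting, with a stated time of 90 min, in the presence of a further agent that is not named here (a higher number here means a weaker inhibitor, a lower number a stronger inhibitor), compound 1 gives 36 nM, the higher of the two numbers measured so far; compound 2 `Cc1cc(OC2CCOCC2)cc(C)c1-c1cccc(COc2ccc(CCC(=O)O)c(F)c2)c1` gives 6.7 nM. Among the measured compounds shown here, the one measured step, a 5.4-fold lower number from compound 1 to compound 2 (0.73 log units; beyond the scatter), comes from an oxan-4-yl)oxy group entering on the far aromatic ring, a different place from the change considered here. Compound 3 `Cc1cccc(C)c1-c1cccc(COc2ccc(CCC(=O)O)cc2)c1` differs from compound 1 by hydrogen in place of fluoro on an aromatic carbon. No measured step in this assay bears on the fluoro; the only comparison available sits elsewhere on the shared core, so the direction is not anchored. The expectation is therefore a small step, a 1.7-fold higher number from compound 1 to compound 3 (0.22 log units; within the scatter), tending toward a somewhat higher number, with the range wide enough to include no change. Compound 3 is estimated at 60 nM, between 20 nM and 180 nM.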

Compound 3, inhibition constant: 27 nM
Estimate against measurement, compound 3: 2.2-fold (0.35 log units) above, and the stated range covers the measured number.
By their numbers in this assay, from the lowest: compound 2; then compounds 3 and 1 (each within the scatter of the next).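

In this assay, hydrogen in place of fluoro on the aromatic carbon ortho to a 2-carboxyethyl group gives a 1.3-fold lower number from compound 1 to compound 3 (0.12 log units; within the scatter) and so does not separate the two substituents at this position on the core of compound 1. Among these compounds, the earlier pair could not show this, since its single step lies at a different place on the shared core. No measurement on hand gives a reason for this result.

On these data alone, whether a larger group at this position, such as chloro, methyl or methoxy, would stay within the scatter of hydrogen remains open. Also open, as far as these compounds go, is whether hydrogen in place of fluoro would read the same with the (oxan-4-yl)oxy group of compound 2 on the far aromatic ring.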